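Swapping the naphthyl for methoxyphenyl on a quinoline core

The source may hold more compounds than are shown below. What is called first, only, known or untested is meant among the compounds shown, and "the series" means these compounds.

Of the compounds shown here, three sharing one core have been measured in a physicochemical assay for solubility, with a stated time of 18 h, at pH 7.4; on this read-out lower numbers stand for lower solubility and higher numbers for higher solubility. Compound 1 `COc1ccc(F)cc1CNCCCNc1ccnc2cc(CCC(C)C)ccc12` gives 4200 nM; compound 2 `COc1ccc(F)cc1CNCCCNc1ccnc2cc(CCc3ccccc3)ccc12` gives 4200 nM; and compound 3 `COc1ccc(F)cc1CNCCCNc1ccnc2cc(-c3cccc4ccccc34)ccc12` gives 32000 nM. Compound 3 stands highest of the three: the step of a 7.6-fold higher number from compound 1 to compound 3 (0.88 log units; beyond the scatter) and the step of a 7.6-fold higher number from compound 2 to compound 3 (0.88 log units; beyond the scatter) are both beyond the scatter, whereas the step of no change at the digits printed from compound 1 to compound 2 (within the scatter) is not.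

Compound 4 `COc1ccc(-c2ccc3c(NCCCNCc4cc(F)ccc4OC)ccnc3c2)cc1` has not yet been measured in this assay. It differs from compound 3 in one place: 4-methoxyphenyl in place of naphthalen-1-yl on an aromatic carbon. An aromatic group remains attached directly to the aromatic carbon, as in compound 3, so the two steps that bear on the change are those from compounds 1 and 2 to compound 3, both modest and both toward a higher number once an aromatic group sits on that carbon. Going by the values given here, no measured step tells what follows when one such aromatic group gives way to a smaller one carrying a hydrogen-bond acceptor. The step of a 1.3-fold higher number from compound 3 to compound 4 (0.10 log units; within the scatter) is therefore expected to be small, with the number more likely to rise than to fall. On that basis compound 4 is estimated at 40000 nM, within a range of 12000 nM to 130000 nM.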

Compound 4, solubility: 32000 nM
Compound 4: the middle estimate sits 1.3-fold (0.10 log units) above what was measured; low and high end bracket the measured number.
By their numbers in this assay, from the lowest: compounds 1 and 2 (each within the scatter of the next); then compounds 3 and 4 (each within the scatter of the next).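

In this assay, 4-methoxyphenyl in place of naphthalen-1-yl on this aromatic carbon gives no change at the digits printed from compound 3 to compound 4 (within the scatter), so one six-membered aromatic ring carrying a hydrogen-bond acceptor and two such rings carrying none cannot be told apart on this read-out. The gap to the chain-linked groups also reappears, with a 7.6-fold higher number from compound 2 to compound 4 (0.88 log units; beyond the scatter) and a 7.6-fold higher number from compound 1 to compound 4 (0.88 log units; beyond the scatter), so the higher number no longer rests on naphthalen-1-yl alone: among the four compounds, both with an aromatic group attached directly to this carbon stand above both with isopentyl or phenethyl there, and none goes against this. Nothing given here explains the result or the gap to the chain-linked groups.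

As far as these compounds go, it remains open whether a plain phenyl, a pyridine ring, or a phenyl ring bearing an amine or a carboxylic acid on this carbon would stay level with compound 3 and compound 4 or move away from them. The compounds shown also leave open whether a short alkyl group such as methyl, or a longer chain ending in a hydroxyl group, would stay level with compound 1 and compound 2.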